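From Fluoro to Trifluoromethyl on Compound 1

The source may hold more compounds than are shown below. What is called first, only, known or untested is meant among the compounds shown, and "the series" means these compounds.

Measured in a functional assay on K562 cells (Homo sapiens) for antiproliferative activity, read by MTT assay, with a stated time of 24 h; a higher number here means a weaker inhibitor, a lower number a stronger inhibitor:
- Compound 1 `COc1ccc(C(=O)/C=C/c2cccc(F)c2)c2c1C=CC(C)(C)O2`: > 10000 nM (a limit)
- Compound 2 `COc1ccc(C(=O)/C=C/c2ccc(Br)cc2)c2c1C=CC(C)(C)O2`: > 10000 nM (a limit)
- Compound 3 `COc1ccc(C(=O)/C=C/c2ccc(N(C)C)cc2)c2c1C=CC(C)(C)O2`: 3500 nM

Compound 1 stands at the limit of > 10000 nM in this assay, at which 2 of the 3 values shown sit, so it has a limit and not a number. Compound 4 `COc1ccc(C(=O)/C=C/c2cccc(C(F)(F)F)c2)c2c1C=CC(C)(C)O2` has yet to be measured. It carries trifluoromethyl in place of fluoro on an aromatic carbon, meta to a large group (trifluoromethyl in place of fluoro on an aromatic carbon).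

Among the compounds with values here, no measured step makes this exchange. The step that the two limits leave unreadable from compound 1 to compound 2 cannot be sized. The steps of an at least 2.8-fold lower number from compound 1 to compound 3 (0.45 log units; beyond the scatter) and an at least 2.8-fold lower number from compound 2 to compound 3 (0.45 log units; beyond the scatter) are the only readable ones, and both bring in dimethylamino, which compound 4 lacks. They therefore give no reason to expect a gain, and no step beyond the scatter is foreseen in this assay. A further limit is the likeliest report. The estimated step is a step that the limit leaves unreadable from compound 1 to compound 4. For compound 4 the expected value is 12000 nM, with an estimated range from 5000 nM to 30000 nM.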

Compound 4, half-maximal inhibitory concentration: 7850 nM
Estimate against measurement, compound 4: 1.5-fold (0.18 log units) above; the measured number falls inside the stated range.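

In this assay, trifluoromethyl in place of fluoro on an aromatic carbon, meta to a large group, gives an at least 1.2-fold lower number from compound 1 to compound 4 (0.10 log units; that floor lies within the scatter). Within the data shown here, compound 4 gives 7850 nM, so in this assay a number at this position does not depend on dimethylamino, the group carried by compound 3, the only earlier compound with a number. Still, no gain over fluoro can be claimed, because compound 1 has only a limit and the step has only a floor, which lies within the scatter: the limit of > 10000 nM in this assay, at which 2 of the 4 values shown sit.

As far as these compounds go, it remains open whether a nitrile or a methoxy group at this position would also give a number in this assay. The compounds shown also leave open what dimethylamino would give at this position, and what trifluoromethyl would give where compound 2 carries bromo.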